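Compound 4: open chain in place of the aryl ring

The source may hold more compounds than are shown below. What is called first, only, known or untested is meant among the compounds shown, and "the series" means these compounds.

Compound 1 `Clc1nc(C#Cc2ccccc2)c2ncn(Cc3ccccc3)c2n1`: 100%
Compound 2 `C(=C/c1ncnc2c1ncn2Cc1ccccc1)\c1ccccc1`: 93%
Compound 3 `COc1ccc(/C=C/c2ncnc3c2ncn3C2CCOCC2)cc1`: 58%

In a functional assay on K562 cells (Homo sapiens) for inhibition, read by thymidine incorporation, with a stated time of 48 h, tested at 10 ug/mL (a higher number here means more inhibition at the concentration tested (going by the name of the read-out), a lower number less inhibition), compound 1 gives 100% and compound 2 gives 93%. Compound 3 gives 58%, the lowest of the three numbers, beyond the scatter below compound 2 and further still below compound 1. Compound 4 `C/C(=C\C=C\c1ncnc2c1ncn2C1CCOCC1)CO` differs from compound 3 in one place: 2-(hydroxymethyl)prop-1-en-1-yl in place of 4-methoxyphenyl on a double-bonded chain carbon bound to a double-bonded chain carbon. No pair of measured compounds differing in one place is available, so the size of such a change cannot be read from the numbers shown. Compound 3 already stands lowest, and a further fall is expected. The step of a number 20 percentage points lower from compound 3 to compound 4 (beyond the scatter) is expected to be a moderate drop in this assay. Compound 4 is estimated at 38%, with a range from 12% to 68%.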

Compound 4, a percentage reported as inhibition, at one concentration (the size of the read-out at that concentration, not a potency): 27%
Compound 4: middle estimate off by 11 percentage points, on the high side, within the range that was stated.
By their numbers in this assay, from the lowest: compound 4; then compound 3; then compounds 2 and 1 (each within the scatter of the next).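

In this assay, the first step read at this position is large: a number 31 percentage points lower from compound 3 to compound 4 (beyond the scatter), with 2-(hydroxymethyl)prop-1-en-1-yl in place of 4-methoxyphenyl. At this place, then, the open chain does not stand in for the aromatic ring without loss of inhibition. No measurement in hand explains the fall.

Ring loss and the arrival of the hydroxymethyl come together in this one step, so the two cannot be told apart. A plain butyl chain or an aminomethyl-bearing chain at the same place would bear on that question.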